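Swapping fluoro for methoxy on the pendant aromatic ring

The source may hold more compounds than are shown below. What is called first, only, known or untested is meant among the compounds shown, and "the series" means these compounds.

Measured so far:
compound 1 `O=C1/C(=C/c2cccc(F)c2)Cc2cc(O)ccc21` — 84 nM
compound 2 `N#Cc1ccc(/C=C2\Cc3cc(O)ccc3C2=O)cc1` — 316 nM

In an assay on isolated protein for inhibition of Amine oxidase [flavin-containing] B (Homo sapiens), read by fluorescence and spectrophotometry, with a stated time of 20 min (a lower number here means a stronger inhibitor, a higher number a weaker inhibitor), compound 1 gives 84 nM, the lowest of the two numbers; in this assay compound 2 gives 316 nM, a gap that lies beyond the scatter. Compound 3 `COc1cccc(/C=C2\Cc3cc(O)ccc3C2=O)c1` has not yet been measured in this assay. It differs from compound 1 by methoxy in place of fluoro on an aromatic carbon. Among the measured compounds shown here, no measured pair shows this change, so the expected step from compound 1 to compound 3 is a 1.8-fold higher number from compound 1 to compound 3 (0.25 log units; within the scatter), a modest weakening that may not exceed the scatter. Compound 3 is estimated at 150 nM, between 50 nM and 450 nM.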

Compound 3, half-maximal inhibitory concentration: 471 nM
Compound 3: the middle estimate sits 3.1-fold (0.50 log units) below what was measured, and the stated range ends below it.
By their numbers in this assay, from the lowest: compound 1; then compounds 2 and 3 (each within the scatter of the next).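

In this assay, putting methoxy in place of fluoro on this aromatic carbon, meta to a large group, gives a 5.6-fold higher number from compound 1 to compound 3 (0.75 log units; beyond the scatter). Among the compounds shown here, this is the first direct reading of this position, and it shows that the position does not treat these two groups alike, with fluoro the better of the pair. Nothing shown here accounts for the difference.

From the compounds shown here alone, it remains open how an amine or a chloro group would read at this same place. Whether methoxy carries a similar cost elsewhere on the pendant ring is also unsettled.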